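Bromo for Methoxy on the Aryl Ring of Compound 2

The compounds below may be only part of what the source reports. "The series", "measured", "known", "first", "only" and "open" are said of these compounds alone.

Within the data shown here, compound 2 `CCOC(=O)c1c(C)[nH]c(=O)c(C#N)c1-c1ccc(OC)cc1` has the lowest number of the two measured so far in an ADME assay on MRC5 cells (Homo sapiens) for cytotoxicity, read by MTT assay, with a stated time of 24 h (a lower number here means a stronger inhibitor, a higher number a weaker inhibitor), giving 192000 nM. Among the measured compounds shown here, its only neighbour, compound 1 `CCOC(=O)c1c(C)[nH]c(=O)c(C#N)c1-c1ccc(C)cc1`, gives 438000 nM in this assay, and the step of a 2.3-fold lower number from compound 1 to compound 2 (0.36 log units; beyond the scatter) is the one measured change. Compound 3 `CCOC(=O)c1c(C)[nH]c(=O)c(C#N)c1-c1ccc(Br)cc1` differs from compound 2 in one place: bromo in place of methoxy on an aromatic carbon. For the measured compounds named here, no measured step bears directly on a bromo replacing a methoxy; the single measured step concerned a methoxy replacing a methyl on the same aromatic carbon and was modest. The expectation is therefore a step of a 1.3-fold higher number from compound 2 to compound 3 (0.11 log units; within the scatter) that stays close to compound 2, with no strong reason to lean either way beyond the scatter. Compound 3 is estimated at 250000 nM in this assay, with a range from 100000 nM to 600000 nM.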

Compound 3, half-maximal inhibitory concentration: 310000 nM
The estimate for compound 3 lay 1.2-fold (0.09 log units) below the measured number; the measured number falls inside the stated range.
By their numbers in this assay, from the lowest: compounds 2, 3 and 1 (each within the scatter of the next, the first and the last beyond it).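

In this assay, placing bromo on this aromatic carbon, para to a large group, gives a 1.6-fold higher number from compound 2 to compound 3 (0.21 log units; within the scatter) and a 1.4-fold lower number from compound 1 to compound 3 (0.15 log units; within the scatter) so both new steps stay within the scatter. Bromo therefore cannot be separated from either methoxy or methyl here, even though those two groups lie beyond the scatter of each other, and the three compounds show no order that includes bromo. Nothing given here explains this result.

The compounds shown leave open whether an amine or a carboxylic acid on this same aromatic carbon would produce a step beyond the scatter from compound 2 or compound 3. They also leave open how much the number depends on the rest of the shared core, such as the nitrile or the ethyl ester.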